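The source may hold more compounds than are shown below. What is called first, only, known or untested is meant among the compounds shown, and "the series" means these compounds.

Three compounds have already been measured in a functional assay on aorta with Alpha-1D adrenergic receptor (Rattus norvegicus) as the target; on this read-out higher numbers stand for an effect only at larger amounts of compound and lower numbers for an effect already at smaller amounts:

Compound 1, `Cn1nc(Cc2ccccc2)c2ccccc2c1=O`, gives <= 10000 nM, which is a limit of the assay and not a number.
Compound 2, `CCn1nc(Cc2ccc(SC)cc2)c2ccccc2c1=O`, gives > 100000 nM, again a limit of the assay rather than a number.
Compound 3, `CCCCn1nc(Cc2ccc(SC)cc2)c2ccccc2c1=O`, gives > 100000 nM, also only a limit of the assay.

Compound 3 therefore stands at the limit of > 100000 nM in this assay, at which 2 of the 3 values shown sit, together with compound 2, whereas compound 1 sits at the limit of <= 10000 nM in this assay, at which 1 of the 3 values shown sits. Among the measured compounds shown here, no measured compound has a true number in this assay. For the measured compounds named here, the only step between measured compounds that differ in one place is a step that the two limits leave unreadable from compound 2 to compound 3; both of its ends are limits, so its size is not readable.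

Compound 4, `CSc1ccc(Cc2nn(C)c(=O)c3ccccc23)cc1`, is still to be measured in this assay. It differs from compound 3 by hydrogen in place of propyl on a saturated chain carbon bound to an aromatic nitrogen. Going by the values given here, no readable measured step bears on this change, and the one step that exists, from compound 2 to compound 3, gives no direction. The expectation for compound 4 therefore rests on little, and is expected to be weak, with the real chance that only a limit is reported again. The estimated step of an at least 3.3-fold lower number from compound 3 to compound 4 (0.52 log units; beyond the scatter) is thus no more than a guess. Compound 4 is estimated at 30000 nM, within a range from 5000 nM to 200000 nM.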

Compound 4, half-maximal effective concentration: 930 nM
Beside the measured number, compound 4's estimate is 32-fold (1.51 log units) above it, and the stated range ends above it.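

In this assay, among the compounds shown here, this position proves sensitive to the chain it carries: hydrogen in place of propyl on a saturated chain carbon bound to an aromatic nitrogen, the change that reads butyl to methyl, gives an at least 100-fold lower number from compound 3 to compound 4 (2.03 log units; beyond the scatter) and yields the first true number. For the compounds shown here, the smaller change at the same place, hydrogen in place of methyl, gives an at least 100-fold lower number from compound 2 to compound 4 (2.03 log units; beyond the scatter) and is thus also large, something the earlier compounds could not show, since they offered only limits and no readable step. Both sizes are bounded by a limit at one end, so the two steps cannot be ranked against each other, and nothing shown gives a cause for them.

The steps from compound 2 to compound 3 and from compound 1 to compound 4 cannot be read, which leaves the contribution of the methylsulfanyl group unsettled. Also open, as far as these compounds go, is how this position would respond to hydrogen on the aromatic nitrogen itself, or to a chain ending in an amine or a carboxylic acid.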